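Permeability of a Piperidine Nitrogen Series

This account rests on a few compounds, and the source may have more. Where it says the series, first, only, none or still open, it means among the compounds named here.

Measured compounds:
compound 1, `Cn1cncc1CN1CC(N(CC2CCN(S(C)(=O)=O)CC2)S(=O)(=O)c2ccccn2)Cc2cc(C#N)ccc21`, 0.1 10^-6 cm/s
compound 2, `Cn1cncc1CN1CC(N(CC2CCN(C(=O)c3ccccc3)CC2)S(=O)(=O)c2ccccn2)Cc2cc(C#N)ccc21`, 0.5 10^-6 cm/s
compound 3, `Cn1cncc1CN1CC(N(CC2CCN(C(=O)OCc3ccccc3)CC2)S(=O)(=O)c2ccccn2)Cc2cc(C#N)ccc21`, 1 10^-6 cm/s

Compound 3 holds the highest number of the three in an ADME assay on Caco-2 cells (Homo sapiens) for permeability, in the apical to basolateral direction; a higher number here means that the compound crosses the layer faster, a lower number that the compound crosses the layer more slowly. Its nearest neighbour is compound 2, and the gap a 2.0-fold higher number from compound 2 to compound 3 (0.30 log units; within the scatter) lies within the scatter, so the two cannot be ranked. The gap to compound 1 is wider: a 10-fold higher number from compound 1 to compound 3 (1.00 log units; beyond the scatter), which is beyond the scatter. The step of a 5.0-fold higher number from compound 1 to compound 2 (0.70 log units; beyond the scatter) is likewise beyond the scatter.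

Compound 4, `CC(C)S(=O)(=O)N1CCC(CN(C2Cc3cc(C#N)ccc3N(Cc3cncn3C)C2)S(=O)(=O)c2ccccn2)CC1`, is the next one to be measured in this assay . It differs from compound 3 in one place: isopropylsulfonyl in place of benzyloxycarbonyl on an amine nitrogen in a ring. Within the data shown here, the step that bears most on this change is the one from compound 1 to compound 3, in which methylsulfonyl gave way to benzyloxycarbonyl on the same amine nitrogen in a ring and raised the number by a 10-fold higher number from compound 1 to compound 3 (1.00 log units; beyond the scatter). Among the measured compounds shown here, the change to compound 4 runs in the opposite sense, bringing a sulfonyl group back to that nitrogen, so a drop beyond the scatter is expected, though not necessarily the full reversal, since no measured compound carries isopropylsulfonyl.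

Compound 4 is therefore expected to give 0.3 10^-6 cm/s in this assay , with a range from 0.1 10^-6 cm/s to 0.8 10^-6 cm/s, a step of a 3.3-fold lower number from compound 3 to compound 4 (0.52 log units; beyond the scatter).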

Compound 4, apparent permeability: 0.1 10^-6 cm/s
The estimate for compound 4 lay 3.0-fold (0.48 log units) above the measured number, within the range that was stated.
By their numbers in this assay, from the lowest: compounds 1 and 4 (each within the scatter of the next); then compounds 2 and 3 (each within the scatter of the next).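

In this assay, the step of a 10-fold lower number from compound 3 to compound 4 (1.00 log units; beyond the scatter) and the step of a 5.0-fold lower number from compound 2 to compound 4 (0.70 log units; beyond the scatter) show that isopropylsulfonyl on this amine nitrogen in a ring goes with a clear drop from both carbonyl-linked groups, so the low number of compound 1 was not peculiar to methylsulfonyl. Exchanging methyl for isopropyl on the sulfonyl sulfur gives no change at the digits printed from compound 1 to compound 4 (within the scatter), so this added bulk on the sulfur leaves the number where it was and does not bring it up towards those of compound 2 and compound 3; across these four compounds, both sulfonyl compounds lie lower than both carbonyl compounds, and none goes against this. Nothing available here accounts for this split between the sulfonyl and carbonyl groups.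

As far as these compounds go, what stays open is whether the higher numbers go with the carbonyl link or with the phenyl ring, since compound 2 and compound 3 carry both and compound 1 and compound 4 carry neither. A phenylsulfonyl group or an acetyl group on this nitrogen would separate the two features, and a free secondary amine there would show how the number stands without either.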